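Replacing bromo with allyl: compound 3 to compound 4

The source may hold more compounds than are shown below. What is called first, only, known or untested is meant among the compounds shown, and "the series" means these compounds.

In an ADME assay on MT2 cells (Homo sapiens) for cytotoxicity, read by XTT assay, with a stated time of 4 days (a lower number here means that less compound is tolerated, a higher number that more compound is tolerated), compound 1 `Cc1cc(C#N)cc(C)c1Oc1ccc(N)c(Nc2ccc(C#N)cc2)n1` reaches only a limit (> 100000 nM) and gives no number. Compound 2 `Cc1cc(Br)cc(C)c1Oc1ccc([N+](=O)[O-])c(Nc2ccc(C#N)cc2)n1` gives 65100 nM and compound 3 `Cc1cc(Br)cc(C)c1Oc1ccc(N)c(Nc2ccc(C#N)cc2)n1` gives 9610 nM as the lower of the two numbers. Bromo in place of cyano is a large step (an at least 10-fold lower number from compound 1 to compound 3 (1.01 log units; beyond the scatter)) and amino in place of nitro a modest one (a 6.8-fold lower number from compound 2 to compound 3 (0.83 log units; beyond the scatter)).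

Compound 4 `C=CCc1cc(C)c(Oc2ccc(N)c(Nc3ccc(C#N)cc3)n2)c(C)c1` carries allyl in place of bromo on an aromatic carbon para to a large group. Only the change at this same place (an at least 10-fold lower number from compound 1 to compound 3 (1.01 log units; beyond the scatter)) bears directly on it, and it shows that the number can move widely there. Within the data shown here, no allyl compound has been measured, so no direction follows, and no step beyond the scatter is expected in this assay for now. The expected result is a 1.2-fold higher number from compound 3 to compound 4 (0.10 log units; within the scatter) with wide uncertainty. Compound 4 is estimated at 12000 nM with an expected range from 3500 nM to 45000 nM in this read-out.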

Compound 4, half-maximal cytotoxic concentration: 14000 nM
For compound 4 the middle estimate is 1.2-fold (0.07 log units) below the measured one; low and high end bracket the measured number.
By their numbers in this assay, from the lowest: compounds 3 and 4 (each within the scatter of the next); then compound 2. At a limit, above all of these: compound 1.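

In this assay, allyl and bromo cannot be told apart at this position, para to a large group (a 1.5-fold higher number from compound 3 to compound 4 (0.16 log units; within the scatter)), so a larger carbon-only group with a double bond outside aromatic rings gives a reading that matches bromo within the scatter. Cyano stays the group that stands apart here, since the allyl compound also lies beyond the scatter from the cyano compound (an at least 7.1-fold lower number from compound 1 to compound 4 (0.85 log units; beyond the scatter)). That step gives only a bound, since compound 1 stands at a limit: the limit of > 100000 nM in this assay, at which 1 of the 4 values shown sits.

On these data alone, whether a propyl chain, an amine or a carboxylic acid at this position would read with allyl and bromo or with cyano stays open. As far as these compounds go, it is also open whether the shift seen between nitro and amino on the bromo compounds carries over to allyl.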